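Swapping a Halide for tert-Butyl: Half-Life Outlook

A few compounds are considered here, and "the series" means these few. Any claim that something is new, unique, unknown or untested is made for them only; others in the source may bear on it.

Measured so far in an in vivo ADME assay on the whole organism (strain Balb/c) for metabolic stability, with Mus musculus as the target, at a dose of 10 mg/kg by the intravenous route; on this read-out higher numbers stand for a longer-lived compound and lower numbers for a shorter-lived compound:
compound 1, `O=C(CCC1=CCN(Cc2ccc(F)cc2)C1=O)NO`, gives 2.6 h
compound 2, `O=C(CCC1=CCN(Cc2ccc(Br)cc2)C1=O)NO`, gives 2.8 h

Compound 2 has the highest of the two numbers in this assay, though its nearest neighbour, compound 1, lies within the scatter of it, so no order between the two can be read. For the measured compounds named here, the only measured step, a 1.1-fold higher number from compound 1 to compound 2 (0.03 log units; within the scatter), shows that exchanging one halogen for another on the aromatic carbon leaves the half-life essentially unchanged.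

Compound 3, `CC(C)(C)c1ccc(CN2CC=C(CCC(=O)NO)C2=O)cc1`, has not yet been measured. It differs from compound 2 as follows: tert-butyl in place of bromo on an aromatic carbon. Going by the values given here, the step from compound 1 to compound 2 is the sole precedent for a change at this aromatic carbon, and it was within the scatter; no measured step speaks to a tert-butyl group, so the data give no reason to expect a shift. The expected step is therefore no change at the digits printed from compound 2 to compound 3 (within the scatter) in this assay, none beyond the scatter. Compound 3 is accordingly expected to give about 2.8 h in this assay, with a range from 1.4 h to 5.6 h.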

Compound 3, half-life in the Mus musculus assay: 7.8 h
The estimate for compound 3 lay 2.8-fold (0.44 log units) below the measured number; the measured number lies above the stated range.
By their numbers in the Mus musculus assay, from the lowest: compounds 1 and 2 (each within the scatter of the next); then compound 3.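

At this position, on an aromatic carbon para to a large group, the half-life proves sensitive to what is attached, a sensitivity the exchange of fluoro and bromo could not show, as that step stayed within the scatter. In the Mus musculus assay, tert-butyl gives a 2.8-fold higher number from compound 2 to compound 3 (0.44 log units; beyond the scatter) and, measured against the fluoro compound, a 3.0-fold higher number from compound 1 to compound 3 (0.48 log units; beyond the scatter), so both halogens sit apart from tert-butyl by a modest but readable margin. The same exchange of bromo for tert-butyl also raises the number in a physicochemical assay for lipophilicity (on this read-out higher numbers stand for higher lipophilicity and lower numbers for lower lipophilicity), where compound 2 gives 1.26 and compound 3 gives 2.1, so the longer half-life of compound 3 comes together with higher lipophilicity, although a single pair cannot show that one follows from the other: the measured distribution coefficient of compound 2, 1.26, and of compound 3, 2.1, a number 0.84 log units higher (beyond the scatter)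

The compounds shown leave open whether the longer half-life belongs to tert-butyl itself or would also appear with other groups on this carbon, such as isopropyl, trifluoromethyl or a methoxy group. They also leave open whether a group that brings in a carboxylic acid or an amine at this place would shorten the half-life again, which would test how closely it tracks the distribution coefficient.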